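From chlorosulfonyl to isopropyl(methyl)sulfamoyl on a shared core

A few compounds are considered here, and "the series" means these few. Any claim that something is new, unique, unknown or untested is made for them only; others in the source may bear on it.

Among the measured compounds shown here, compound 1 (`CCOC(=O)c1cnc(-c2cc(OC)ccc2OCC)[nH]c1=O`) supplies the only number in this small set: in a functional assay on the whole organism (strain Sprague-Dawley) for inhibition, with Rattus norvegicus as the target, with a stated time of 10 min (a lower number here means that less compound is needed, a higher number that more compound is needed for the effect), compound 1 gives 0.3 mg/kg as its dose. Compound 2 (`CCOC(=O)c1cnc(-c2cc(S(=O)(=O)Cl)ccc2OCC)[nH]c1=O`) carries a chlorosulfonyl group on the shared core, and the entry for compound 2 reads "not determined" (no result reported) with no figure behind it. It therefore has no place on the scale and offers no starting point for a step.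

Compound 3 (`CCOC(=O)c1cnc(-c2cc(S(=O)(=O)N(C)C(C)C)ccc2OCC)[nH]c1=O`) differs from compound 2 by having isopropyl(methyl)amino in place of chloro on a sulfonyl sulfur. Read one bond further out, chlorosulfonyl becomes isopropyl(methyl)sulfamoyl. For the measured compounds named here, no measured step shows what such a change does in this assay here, so the only anchor is compound 1 at 0.3 mg/kg as its one measured dose. Against that anchor, a small rise of about the size of the scatter is expected, meaning slightly more compound would be needed, though the uncertainty is wide. Compound 3 is estimated at 0.6 mg/kg with an expected range from 0.1 mg/kg to 3 mg/kg as its likely span.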

Compound 3, dose for 50% inhibition: > 10 mg/kg
Compound 3 gave a limit, no number; the forecaster's own chance of this, stated with the estimate: 10%; at least 16-fold (1.22 log units) between middle value and limit.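

Compound 3 gives > 10 mg/kg in this assay, and this value is a limit of the assay, not a number. Among the compounds shown here, this is the first measured sign that the group on this aromatic carbon matters: isopropyl(methyl)sulfamoyl in place of methoxy gives an at least 33-fold higher number from compound 1 to compound 3 (1.52 log units; beyond the scatter), so the effect that compound 1 reaches at a small dose is not reached by compound 3 at any dose tested. The full size of this step stays unknown, and the comparison can only be read as a minimum: the limit of > 10 mg/kg in this assay, at which 1 of the 3 values shown sits.

Compound 2 has no figure, so the steps from it cannot be read, and the exchange of chloro for isopropyl(methyl)amino on the sulfonyl sulfur has no measured effect of its own. The compounds shown also do not separate the sulfonyl unit itself from the isopropyl and methyl groups on its nitrogen, a question on which a sulfamoyl group with an unsubstituted amino nitrogen, or a piperazine attached to the sulfur, would bear directly.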